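The source may hold more compounds than are shown below. What is called first, only, known or untested is meant among the compounds shown, and "the series" means these compounds.

Measured in a functional assay on MGC-803 cells (Homo sapiens) for inhibition, read by MTT assay, with a stated time of 48 h; on this read-out lower numbers stand for stronger inhibition and higher numbers for weaker inhibition:
compound 1 `COc1ccc(CN(C(=O)C=C(C)C)c2cc(OC)c(OC)c(OC)c2)cc1O`: 320 nM
compound 2 `CCC/C=C/C(=O)N(Cc1ccc(OC)c(O)c1)c1cc(OC)c(OC)c(OC)c1`: 70 nM
compound 3 `COc1ccc(CN(C(=O)CN=[N+]=[N-])c2cc(OC)c(OC)c(OC)c2)cc1O`: 120 nM

Of these three, compound 3 cannot be told apart from compound 2, as the data show a 1.7-fold higher number from compound 2 to compound 3 (0.23 log units; within the scatter). Compound 1 stands apart, with a 2.7-fold lower number from compound 1 to compound 3 (0.43 log units; beyond the scatter).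

Compound 4 `COc1ccc(CN(C(=O)C2CC2)c2cc(OC)c(OC)c(OC)c2)cc1O` has cyclopropyl in place of azidomethyl on a carbonyl carbon.

The measured steps that bear on this change are those at the same place. They are a 4.6-fold lower number from compound 1 to compound 2 (0.66 log units; beyond the scatter) and a 2.7-fold lower number from compound 1 to compound 3 (0.43 log units; beyond the scatter), and both are modest. The step between compound 2 and compound 3 stays within the scatter. Among the compounds with values here, none of the measured compounds carries a ring at this place, so the data give no firm direction. In this assay, no step beyond the scatter is therefore expected. The expected step is a 1.2-fold higher number from compound 3 to compound 4 (0.07 log units; within the scatter). For compound 4 the estimated value is 140 nM, with an expected range of 50 nM to 400 nM.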

Compound 4, half-maximal inhibitory concentration: 59 nM
For compound 4 the middle estimate is 2.4-fold (0.38 log units) above the measured one; low and high end bracket the measured number.
By their numbers in this assay, from the lowest: compounds 4, 2 and 3 (each within the scatter of the next, the first and the last beyond it); then compound 1.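

In this assay, within the data shown here, a ring is accepted at this place, on a carbonyl carbon whose other neighbour is an amide-type nitrogen, which none of the earlier compounds could show. Cyclopropyl improves on both azidomethyl (a 2.0-fold lower number from compound 3 to compound 4 (0.31 log units; beyond the scatter)) and 2-methylprop-1-en-1-yl (a 5.4-fold lower number from compound 1 to compound 4 (0.73 log units; beyond the scatter)), while cyclopropyl and pent-1-en-1-yl cannot be told apart (a 1.2-fold lower number from compound 2 to compound 4 (0.07 log units; within the scatter)), so the open pent-1-en-1-yl chain and the small ring serve equally well here. No measurement given here accounts for these differences.

The compounds shown leave open whether a larger ring, such as cyclobutyl, cyclohexyl or phenyl, would hold this level, and whether a saturated chain such as butyl would match pent-1-en-1-yl. They also do not tell how an amine or a carboxylic acid would fare at this place.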